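This account rests on a few compounds, and the source may have more. Where it says the series, first, only, none or still open, it means among the compounds named here.

Measured so far in a physicochemical assay for lipophilicity, at pH 7.4; a higher number here means a more lipophilic compound, a lower number a more polar compound:
- compound 1 `Cc1cc(C(=O)O)nn1C(C)c1cc(Cl)ccc1OCc1ccccc1` gives 1
- compound 2 `Cc1cc(C(=O)NN2CCOCC2)nn1Cc1cc(Cl)ccc1OCC(C)C` gives 3.1
- compound 3 `Cc1cc(NC(=O)CC2CCCCC2)nn1Cc1cc(Cl)ccc1OCc1ccccc1` gives 3.2

Compound 2 at 3.1 lies within the usual scatter of compound 3 at 3.2, so these two numbers cannot be told apart. Both stand well clear of compound 1 at 1, a gap beyond the scatter.

The next compound to be measured is compound 4 `Cc1cc(NC(=O)OC(C)(C)C)nn1Cc1cc(Cl)ccc1OCC(C)C`, which differs from compound 2 in one place: (tert-butoxycarbonyl)amino in place of (morpholin-4-yl)carbamoyl on an aromatic carbon. Put simply, (tert-butoxycarbonyl)amino takes the place of (morpholin-4-yl)carbamoyl on an aromatic carbon. The group that leaves holds one six-membered non-aromatic ring with 2 hetero atoms, while the group that enters has no ring.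

For the measured compounds named here, no two measured compounds differ in just one place, so the data give no direct guide to the size of this step. Compound 2 and compound 3 differ in several places yet stay within the scatter of each other, while compound 1 shows that much larger gaps do occur. A modest rise in this assay is expected, probably just beyond the scatter, and the estimated change a number 0.60 log units higher from compound 2 to compound 4 (beyond the scatter) reflects this. For compound 4 the expected value is 3.7, with an estimated range from 3.1 to 4.4.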

Compound 4, distribution coefficient: > 3.7
Compound 4: no number, only a limit (the forecaster's own chance of this, stated with the estimate: 3%); the middle value sits exactly at the limit.
By their numbers in this assay, from the lowest: compound 1; then compounds 2 and 3 (each within the scatter of the next). At a limit, above all of these: compound 4.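

For the compounds shown here, compound 2 and compound 4 are the first measured pair that differ in one place only, so this is the first direct reading of a change on an aromatic carbon of a five-membered aromatic ring with 2 nitrogen. In this assay, putting (tert-butoxycarbonyl)amino in place of (morpholin-4-yl)carbamoyl gives a number at least 0.60 log units higher from compound 2 to compound 4 (beyond the scatter), so this single change is enough to move the reading beyond the scatter, and in the upward direction. The reading for compound 4 is a limit and not a number: the limit of > 3.7 in this assay, at which 1 of the 4 values shown sits.

Going by these compounds, the swap takes away a six-membered non-aromatic ring with 2 hetero atoms and brings in a group with no ring, but a single step cannot show which part of the change matters, and how far compound 4 lies past its limit also stays unknown. The compounds shown also leave open what a free amine, a hydroxyl group or a nitrile would give on this same aromatic carbon, with the rest of compound 2 unchanged.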